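The source may hold more compounds than are shown below. What is called first, only, known or untested is meant among the compounds shown, and "the series" means these compounds.

compound 1 `CC1=CC[C@H]2[C@H](CC[C@]2(C)O)C(C)(C)[C@@H]1CC[C@H]1[C@]2(C)CC[C@H](OC(=O)c3ccccc3)C(C)(C)O[C@H]2CC[C@@]1(C)O` gives 16100 nM
compound 2 `CC1=CC[C@H]2[C@H](CC[C@]2(C)O)C(C)(C)[C@@H]1CC[C@H]1[C@]2(C)CC[C@H](OC(=O)c3ccncc3)C(C)(C)O[C@H]2CC[C@@]1(C)O` gives 18000 nM
compound 3 `CC1=CC[C@H]2[C@H](CC[C@]2(C)O)C(C)(C)[C@@H]1CC[C@H]1[C@]2(C)CC[C@H](OC(=O)c3ccc(Cl)cc3)C(C)(C)O[C@H]2CC[C@@]1(C)O` gives 10300 nM

All three numbers come from a functional assay on MDA-MB-231 cells (Homo sapiens) for antiproliferative activity, read by MTT assay, with a stated time of 72 h; a higher number here means a weaker inhibitor, a lower number a stronger inhibitor. Compound 3 does not stand apart from the other two compounds. The measured steps to it are a 1.6-fold lower number from compound 1 to compound 3 (0.19 log units; within the scatter) and a 1.7-fold lower number from compound 2 to compound 3 (0.24 log units; within the scatter), and the remaining step is a 1.1-fold higher number from compound 1 to compound 2 (0.05 log units; within the scatter). All of these stay within the usual scatter of repeated measurements, so the three compounds cannot be told apart.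

The next compound is compound 4 `CC1=CC[C@H]2[C@H](CC[C@]2(C)O)C(C)(C)[C@@H]1CC[C@H]1[C@]2(C)CC[C@H](OCc3ccccc3)C(C)(C)O[C@H]2CC[C@@]1(C)O`, which has benzyl in place of (4-chlorophenyl)carbonyl on an oxygen on a saturated carbon.

The measured steps give only partial guidance for this change. From the compounds shown here alone, they swap the ring on the carbonyl carbon or add chloro to an aromatic carbon, but none removes the carbonyl, so that part of the change is untested. The loss of chloro is better covered, since compound 1, which has no chloro, gives 16100 nM. On this evidence, no step beyond the scatter is expected, in either direction, though with real uncertainty. The expected change is a 1.5-fold higher number from compound 3 to compound 4 (0.16 log units; within the scatter). The estimated value for compound 4 is 15000 nM, with an expected range from 6000 nM to 40000 nM.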

Compound 4, half-maximal inhibitory concentration: 29100 nM
Compound 4: the middle estimate sits 1.9-fold (0.29 log units) below what was measured; low and high end bracket the measured number.
By their numbers in this assay, from the lowest: compounds 3, 1, 2 and 4 (each within the scatter of the next, the first and the last beyond it).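

In this assay, for the compounds shown here, benzyl in place of (4-chlorophenyl)carbonyl on this oxygen gives a 2.8-fold higher number from compound 3 to compound 4 (0.45 log units; beyond the scatter), the first step to pass beyond the scatter, so changing the link to the ring here can matter where swapping the ring on the carbonyl carbon did not. The other two new steps are smaller: benzyl in place of benzoyl gives a 1.8-fold higher number from compound 1 to compound 4 (0.26 log units; within the scatter), and benzyl in place of (pyridin-4-yl)carbonyl gives a 1.6-fold higher number from compound 2 to compound 4 (0.21 log units; within the scatter), both within the scatter, so without chloro in the comparison the loss of the carbonyl cannot be told from noise. Going by these compounds alone, the one clear step therefore combines two differences, the carbonyl and the chloro, and no measurement at hand explains it.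

A 4-chlorobenzyl group on this oxygen would separate those two differences, and the compounds shown leave open how it would compare with compound 3 and compound 4. Also open, from the compounds shown here alone, is what a free hydroxyl, an amine-bearing chain or a longer chain such as phenethyl would do at this place.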